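Piperazine nitrogen substituent: aryl to arylpropyl chain

The compounds below may be only part of what the source reports. "The series", "measured", "known", "first", "only" and "open" are said of these compounds alone.

Three compounds of the series carry a shared core with varying groups on the piperazine nitrogen. Compound 1 `Nc1scc(CN2CCN(c3ccc(Cl)c(C(F)(F)F)c3)CC2)c1C(=O)c1ccc(Cl)cc1` in a functional assay on CHO cells with adenosine receptor A1 (Homo sapiens) as the target, read by cAMP accumulation and immunoassay, with a stated time of 6 min, tested at 0.1 uM (a higher number here means a weaker effect of the compound at the concentration tested, a lower number a stronger effect), gives -12%. Compound 2 `Nc1scc(CN2CCN(c3cccc4ccccc34)CC2)c1C(=O)c1ccc(Cl)cc1` in this assay gives 0%. Compound 3 `Nc1scc(CN2CCN(c3ccc(F)c(F)c3)CC2)c1C(=O)c1ccc(Cl)cc1` in this assay gives -34%, the lowest of the three numbers; the nearest is compound 1 with a number 22 percentage points lower from compound 1 to compound 3 (beyond the scatter), the furthest compound 2 with a number 34 percentage points lower from compound 2 to compound 3 (beyond the scatter), and the remaining measured step is a number 12 percentage points higher from compound 1 to compound 2 (beyond the scatter).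

Compound 4 `Nc1scc(CN2CCN(CCCc3ccc(Cl)cc3)CC2)c1C(=O)c1ccc(Cl)cc1` is not yet measured. Its difference from compound 3 is 3-(4-chlorophenyl)propyl in place of 3,4-difluorophenyl on an amine nitrogen in a ring. For the measured compounds named here, all three measured steps exchange one six-membered aromatic ring for another on that nitrogen; none exchanges an aromatic ring directly on the nitrogen for a 3-(4-chlorophenyl)propyl chain, so no step bears on this change closely. What the measured steps do show is that the group on this nitrogen moves the number by modest to large amounts, and that compound 3 sits at the low end while compound 2 sits at the high end.

Given that the nearest structural precedents are only indirect, a step toward the higher numbers of compound 1 and compound 2 is expected, of modest size, a number 22 percentage points higher from compound 3 to compound 4 (beyond the scatter). The estimate for compound 4 in this assay is -12%, with a range from -40% to 14%.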

Compound 4, a percentage reported as activity, at one concentration (the size of the read-out at that concentration, not a potency): -3%
Estimate against measurement, compound 4: 9 percentage points below; low and high end bracket the measured number.
By their numbers in this assay, from the lowest: compound 3; then compounds 1, 4 and 2 (each within the scatter of the next, the first and the last beyond it).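

The 3-(4-chlorophenyl)propyl group is the only one in the set that places a chain rather than an aromatic ring directly on the amine nitrogen in a ring, and in this assay the exchange gives a number 31 percentage points higher from compound 3 to compound 4 (beyond the scatter), a large step. The other two exchanges stay within the scatter, with a number 3 percentage points lower from compound 2 to compound 4 (within the scatter) and a number 9 percentage points higher from compound 1 to compound 4 (within the scatter), so an aromatic ring directly on this nitrogen is not needed to reach the range of compound 1 and compound 2, and compound 3 remains apart from the other three. No measurement at hand accounts for the large step from the 3,4-difluorophenyl group or for the closeness of the other values.

Still open, as far as these compounds go, is the part played by chain length, which a 2-(4-chlorophenyl)ethyl or a longer 4-(4-chlorophenyl)butyl group on this nitrogen would address. Also open, from the compounds shown here alone, is the part played by the ring at the end of the chain, which a 3-(3,4-difluorophenyl)propyl group would separate from the effect of the chain itself.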